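Removing the aryl methyl: compound 1 to compound 3

The source may hold more compounds than are shown below. What is called first, only, known or untested is meant among the compounds shown, and "the series" means these compounds.

Among the compounds with values here, compound 1 `COc1ccc(-c2cnc3nc(N)nc(N4CCN(c5ccc(C)cc5)CC4)c3n2)cc1OC` is the only member of the series with a numerical result in a functional assay on cells (T-cell, Homo sapiens) for inhibition (on this read-out lower numbers stand for stronger inhibition and higher numbers for weaker inhibition), where compound 1 gives 300 nM. Compound 2 `CC(C)Oc1nc(N)nc2ncc(-c3ccc(C(F)(F)F)cc3)nc12` is recorded in this assay only as a limit, at > 10000 nM, which is the assay limit rather than a number (the limit of > 10000 nM in this assay, at which 1 of the 2 values shown sits). Within the data shown here, no step between two measured compounds is available, so the size of the change from compound 1 to compound 3 `COc1ccc(-c2cnc3nc(N)nc(N4CCN(c5ccccc5)CC4)c3n2)cc1OC` has to be judged from the structures alone. The difference is hydrogen in place of methyl on an aromatic carbon, that is, 4-methylphenyl becomes phenyl on an aromatic carbon of a six-membered aromatic ring of carbon only. A change of this kind, a single carbon at the edge of the molecule, is expected to give at most a small step in this assay, with a slight weakening more likely than a gain, and probably not beyond the scatter. Compound 3 is therefore expected to give about 450 nM, in the range 150 nM to 1400 nM. The expected step is estimated at a 1.5-fold higher number from compound 1 to compound 3 (0.18 log units; within the scatter).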

Compound 3, half-maximal inhibitory concentration: 400 nM
Estimate against measurement, compound 3: 1.1-fold (0.05 log units) above; the range from low to high includes it.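

In this assay, within the data shown here, the first step that can be read is a 1.3-fold higher number from compound 1 to compound 3 (0.12 log units; within the scatter), which shows that methyl on this aromatic carbon, para to a large group, can give way to hydrogen without a change that stands out from the scatter. For this pair, then, the 4-methylphenyl and phenyl groups cannot be told apart on this read-out, and the single carbon makes no measurable difference. No recorded evidence bears on this step.

Methyl and hydrogen are the only substituents shown at this place, so it remains open whether a larger or more differently built group, such as an ethyl chain, an amine or a carboxylic acid, would give a step beyond the scatter. Also open, from the compounds shown here alone, is how a chlorine atom or a hydroxyl group on the same carbon would compare with compound 3.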